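The source may hold more compounds than are shown below. What is called first, only, known or untested is meant among the compounds shown, and "the series" means these compounds.

In a functional assay on WM 266-4 cells (Homo sapiens) for antiproliferative activity, read by MTT assay, with a stated time of 24 h (on this read-out higher numbers stand for weaker inhibition of growth and lower numbers for stronger inhibition of growth), compound 1 `Clc1ccc(C2CC(c3ccc4c(c3)OCCO4)=NN2c2ccccc2)cc1` gives 38600 nM and compound 2 `Ic1ccc(C2CC(c3ccc4c(c3)OCCO4)=NN2c2ccccc2)cc1` gives 3470 nM, the step of an 11-fold lower number from compound 1 to compound 2 (1.05 log units; beyond the scatter) being beyond the scatter. Compound 3 `c1ccc(N2N=C(c3ccc4c(c3)OCCO4)CC2c2cccc3ccccc23)cc1` reaches only the limit of this assay, > 100000 nM, so no number is known for it. On the values shown it sits at the weak end of the set. Compound 4 `Cc1ccc(C2CC(c3ccc4c(c3)OCCO4)=NN2c2ccccc2)cc1` differs from compound 3 in one place: 4-methylphenyl in place of naphthalen-1-yl on a saturated ring carbon. The measured steps that bear on this change ran the opposite way, an at least 2.5-fold higher number from compound 1 to compound 3 (0.41 log units; beyond the scatter) and an at least 28-fold higher number from compound 2 to compound 3 (1.45 log units; beyond the scatter), both beyond the scatter, so putting 4-methylphenyl in place of naphthalen-1-yl is expected to lower the number by a large step of an at least 3.3-fold lower number from compound 3 to compound 4 (0.52 log units; beyond the scatter). Compound 4 is therefore estimated at 30000 nM, within 8000 nM to 100000 nM.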

Compound 4, concentration for 50% growth inhibition: 2530 nM
Beside the measured number, compound 4's estimate is 12-fold (1.07 log units) above it; measured number outside the range, below it.
By their numbers in this assay, from the lowest: compounds 4 and 2 (each within the scatter of the next); then compound 1. At a limit, above all of these: compound 3.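

In this assay the saturated ring carbon carries 4-methylphenyl far better than naphthalen-1-yl, with an at least 39-fold lower number from compound 3 to compound 4 (1.59 log units; beyond the scatter) as a bound only, as compound 3 stands at a limit: the limit of > 100000 nM in this assay, at which 1 of the 4 values shown sits. On the aromatic carbon, methyl in place of chloro gives a 15-fold lower number from compound 1 to compound 4 (1.18 log units; beyond the scatter) and so matches the gain seen with iodo, while methyl in place of iodo gives a 1.4-fold lower number from compound 2 to compound 4 (0.14 log units; within the scatter) and leaves compound 2 and compound 4 level. The compounds shown leave open how an amine, a hydroxyl or a longer alkyl chain on that aromatic carbon would read.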